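Fluoro in Place of Chloro: From Compound 2 to Compound 3

The compounds below may be only part of what the source reports. "The series", "measured", "known", "first", "only" and "open" are said of these compounds alone.

Among the compounds with values here, compound 2 `O=C(/C=C/c1ccc(Cl)cc1)Nc1ccc2c(c1)OCCO2` gives 320 nM in a functional assay on CHO cells for inhibition of transient receptor potential cation channel subfamily V member 1 (Homo sapiens) (on this read-out lower numbers stand for stronger inhibition and higher numbers for weaker inhibition), the higher of the two numbers measured so far; compound 1 `CC(C)c1ccc(/C=C/C(=O)Nc2ccc3c(c2)OCCO3)cc1` gives 82 nM. Within the data shown here, the only step at hand, a 3.9-fold higher number from compound 1 to compound 2 (0.59 log units; beyond the scatter), replaced isopropyl with chloro on an aromatic carbon and raised the number beyond the scatter. Compound 3 `O=C(/C=C/c1ccc(F)cc1)Nc1ccc2c(c1)OCCO2` carries a further change at that aromatic carbon: fluoro in place of chloro on an aromatic carbon. Since the earlier step raised the number, a further rise is expected, modest in size, as a 2.5-fold higher number from compound 2 to compound 3 (0.40 log units; beyond the scatter). Compound 3 is therefore estimated at 800 nM, between 250 nM and 2500 nM.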

Compound 3, half-maximal inhibitory concentration: > 4000 nM
Compound 3: only a limit was reported (the forecaster's own chance of this, stated with the estimate: 5%); at least 5.0-fold (0.69 log units) between middle value and limit.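

In this assay, fluoro in place of chloro on this aromatic carbon gives an at least 12-fold higher number from compound 2 to compound 3 (1.09 log units; beyond the scatter), a step larger than the earlier change at the same carbon, a 3.9-fold higher number from compound 1 to compound 2 (0.59 log units; beyond the scatter). Across the groups shown here, the number rises from isopropyl through chloro to fluoro, with an at least 48-fold higher number from compound 1 to compound 3 (1.68 log units; beyond the scatter). For compound 3 the result is a limit and not a number: the limit of > 4000 nM in this assay, at which 1 of the 3 values shown sits.

From the compounds shown here alone, how far compound 3 lies past its limit stays open. Also open, going by these compounds, is whether a tert-butyl, a trifluoromethyl or a methoxy group on this carbon would give a lower number than isopropyl.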